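Aromatic substituent changes on the shared core

The source may report more compounds than this note shows. Statements on the series, on what has been measured and on what is new or still open speak of the compounds shown alone.

Measured so far:
compound 1 `COC1=C(C)C(=O)/C(=C(O)/C=C/c2ccc(Br)cc2)C(=O)C1(C)C` in a functional assay on HUVEC cells (Homo sapiens) (a lower number here means that less compound is needed, a higher number that more compound is needed for the effect), gives < 4 ug/mL.
compound 2 `COC1=C(C)C(=O)/C(=C(O)/C=C/c2ccc(OC)cc2)C(=O)C1(C)C` in this assay gives < 4 ug/mL.

Both values are limits of this assay and not numbers. The value of compound 1 is a limit. The value of compound 2 is likewise a limit. The change a step that the two limits leave unreadable from compound 1 to compound 2 is thus of unknown size, and compound 2 stands at the limit of < 4 ug/mL in this assay, at which 2 of the 2 values shown sit, with no numeric position within that range.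

Compound 3 `COC1=C(C)C(=O)/C(=C(O)/C=C/c2ccc(O)cc2)C(=O)C1(C)C` differs from compound 2 by hydrogen in place of methyl on an oxygen on an aromatic ring. Within the data shown here, the only measured step that touches the aromatic substituent is the one from compound 1 to compound 2, and its size is not readable, so neither size nor direction can be taken from it. For compound 3 in this assay a step that the limit leaves unreadable from compound 2 to compound 3 of undetermined direction is expected, most likely again reported as a limit. Compound 3 is estimated at 2 ug/mL, within the range 0.5 ug/mL to 8 ug/mL.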

Compound 3, concentration for half-maximal effect: < 4 ug/mL
Compound 3: a limit, no number; the forecaster's own chance of this, stated with the estimate: 50%; the middle value lies beyond the limit too.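

No step among compound 1, compound 2 and compound 3 can be read in this assay, since each value is a limit: the limit of < 4 ug/mL in this assay, at which 3 of the 3 values shown sit.

The compounds shown leave open where the true values lie and whether changing the aromatic substituent among bromo, methoxy and hydroxy shifts the value at all.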